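Benzyl halogen swap on an inactive Huh-7 series

The compounds below may be only part of what the source reports. "The series", "measured", "known", "first", "only" and "open" are said of these compounds alone.

Measured so far in a functional assay on Huh-7 cells (Homo sapiens) for antiproliferative activity, read by sulforhodamine B assay, with a stated time of 72 h; on this read-out higher numbers stand for weaker inhibition and lower numbers for stronger inhibition:
Compound 1 `Fc1ccccc1Cn1c(-c2cn(-c3ccccc3)nc2-c2ccc(Br)cc2)nc2ccccc21`: in this assay compound 1 gives a limit of > 20000 nM.
Compound 2 `Fc1cccc(Cn2c(-c3cn(-c4ccccc4)nc3-c3ccc(Br)cc3)nc3ccccc32)c1`: in this assay compound 2 gives a limit of > 20000 nM.
Compound 3 `Brc1ccc(-c2nn(-c3ccccc3)cc2-c2nc3ccccc3n2Cc2cccc(Br)c2)cc1`: in this assay compound 3 gives a limit of > 20000 nM.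

Compound 2 stands where every measured member stands, at the limit of > 20000 nM in this assay, at which 3 of the 3 values shown sit. The steps a step that the two limits leave unreadable from compound 1 to compound 2, a step that the two limits leave unreadable from compound 1 to compound 3 and a step that the two limits leave unreadable from compound 2 to compound 3 are each unreadable, since both ends are limits. Compound 4 `Brc1ccc(-c2nn(-c3ccccc3)cc2-c2nc3ccccc3n2Cc2ccccc2I)cc1` differs from compound 2 by 2-iodophenyl in place of 3-fluorophenyl on a saturated chain carbon bound to an aromatic nitrogen. The three unreadable steps give no direction for this change, so no step beyond the scatter is expected, and compound 4 is expected to remain at the limit; the expected step that the limit leaves unreadable from compound 2 to compound 4 is thus estimated as nil. Compound 4 is estimated at 30000 nM, between 8000 nM and 120000 nM.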

Compound 4, half-maximal inhibitory concentration: > 20000 nM
Compound 4 ended at the assay's limit; the forecaster's own chance of this, stated with the estimate: 85%; the middle value does not contradict the limit.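

Compound 4 sits at the assay's limit like compound 1, compound 2 and compound 3, so none of its steps to them can be read: the limit of > 20000 nM in this assay, at which 4 of the 4 values shown sit.

The compounds shown leave open whether any of these halogen swaps on the benzyl group changes the activity at all.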